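Swapping an Ester for a Nitro Group on a Hydrazone

This account rests on a few compounds, and the source may have more. Where it says the series, first, only, none or still open, it means among the compounds named here.

Three compounds share a core in which an aromatic bicyclic unit is joined through a benzene ring to an acyl hydrazone, and they differ only in the group carried by the far benzene ring. Compound 1 `O=C(N/N=C/c1ccc(O)cc1)c1ccc(-c2nc3ccccc3s2)cc1` carries a hydroxy group there; in an assay on isolated protein for inhibition of Maltase-glucoamylase (Homo sapiens), with a stated time of 15 min (a higher number here means a weaker inhibitor, a lower number a stronger inhibitor), compound 1 gives 11300 nM, which is weak inhibition. Among the compounds with values here, compound 2 `COC(=O)c1ccc(/C=N/NC(=O)c2ccc(-c3nc4ccccc4s3)cc2)cc1` carries a methoxycarbonyl group instead, and in this assay compound 2 is reported as "not active" (no number reported), so no single number can be assigned to it, and no measured step can be drawn from it to any other compound.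

Compound 3 `O=C(N/N=C/c1ccc([N+](=O)[O-])cc1)c1ccc(-c2nc3ccccc3s2)cc1` is the next variation; its structural change from compound 2 is nitro in place of methoxycarbonyl on an aromatic carbon.

Within the data shown here, with no measured step available to guide the size of this change, the expectation for compound 3 in this assay rests only on the weak result of compound 1, which gave 11300 nM, and on the report of compound 2 as "not active" (no number reported). Compound 3 is therefore expected to remain a weak inhibitor, with an estimated value of 25000 nM, somewhere between 8000 nM and 100000 nM, and a real chance that it is again reported as inactive.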

Compound 3, half-maximal inhibitory concentration: 26400 nM
Estimate against measurement, compound 3: 1.1-fold (0.02 log units) below; measured number inside the range.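

In this assay compound 3 gives 26400 nM, so this carbon can carry a group other than hydroxy and still yield a number, which compound 2, reported as "not active", did not show. Nitro and methoxycarbonyl match in their counted hydrogen-bond donors and acceptors, yet only the nitro compound has a number, so those counts alone do not separate the two results, and the size of this change cannot be read. Nitro in place of hydroxy brings a 2.3-fold higher number from compound 1 to compound 3 (0.37 log units; beyond the scatter). Nothing measured here accounts for this step or for the difference between compound 2 and compound 3.

On these data alone, whether an amine, a carboxylic acid or a methoxy group on this carbon would give a number nearer to that of compound 1, a higher one, or none at all remains open. As far as these compounds go, with only hydroxy, methoxycarbonyl and nitro to compare, it also remains open whether any group here could turn this weak inhibition into strong inhibition.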